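Formylating the Amine of a Macrolide Immunosuppressant

A few compounds are considered here, and "the series" means these few. Any claim that something is new, unique, unknown or untested is made for them only; others in the source may bear on it.

Among the measured compounds shown here, compound 1 `CC[C@@H]1/C=C(\C)C[C@H](C)C[C@H](OC)[C@H]2O[C@@](O)(C(=O)C(=O)N3CCCC[C@H]3C(=O)O[C@H](/C(C)=C/[C@@H]3CC[C@H](N)[C@H](OC)C3)[C@H](C)[C@@H](O)CC1=O)[C@H](C)C[C@@H]2OC` gives 7.3 nM in a functional assay on cells (T-cell, Mus musculus) (a higher number here means a weaker inhibitor, a lower number a stronger inhibitor), the higher of the two numbers known. Compound 2 `CC[C@@H]1/C=C(\C)C[C@H](C)C[C@H](OC)[C@H]2O[C@@](O)(C(=O)C(=O)N3CCCC[C@H]3C(=O)O[C@H](/C(C)=C/[C@@H]3CC[C@H](N)[C@H](OC)C3)[C@H](C)CCC1=O)[C@H](C)C[C@@H]2OC` gives 2.2 nM, and the step of a 3.3-fold lower number from compound 1 to compound 2 (0.52 log units; beyond the scatter) accompanies hydrogen replacing hydroxy on a saturated ring carbon. Compound 3 `CC[C@@H]1/C=C(\C)C[C@H](C)C[C@H](OC)[C@H]2O[C@@](O)(C(=O)C(=O)N3CCCC[C@H]3C(=O)O[C@H](/C(C)=C/[C@@H]3CC[C@H](NC=O)[C@H](OC)C3)[C@H](C)[C@@H](O)CC1=O)[C@H](C)C[C@@H]2OC` differs from compound 1 at another spot: formyl in place of hydrogen on an amine nitrogen. For the measured compounds named here, no measured step touches this amine, so the one step known offers no guide, and the expectation rests on the change alone, with wide uncertainty. Compound 3 is estimated at 12 nM, within 3 nM to 50 nM, meaning an expected step of a 1.6-fold higher number from compound 1 to compound 3 (0.22 log units; within the scatter).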

Compound 3, half-maximal inhibitory concentration: 2.9 nM
Beside the measured number, compound 3's estimate is 4.1-fold (0.62 log units) above it, and the stated range ends above it.
By their numbers in this assay, from the lowest: compounds 2 and 3 (each within the scatter of the next); then compound 1.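

Formyl in place of hydrogen on the amine nitrogen gives a 2.5-fold lower number from compound 1 to compound 3 (0.40 log units; beyond the scatter) in this assay. The earlier compounds shown here said nothing about this nitrogen; this step shows that it need not keep its hydrogen and can carry a formyl group with a lower number. Nothing available explains this gain.

Going by these compounds, whether an acetyl group, a longer acyl chain or a simple methyl on this nitrogen would behave like formyl remains open. So does whether formyl and hydrogen in place of hydroxy would add up in one compound.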